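Removing the ring fluorine from the piperazine-linked quinazoline

The source may report more compounds than this note shows. Statements on the series, on what has been measured and on what is new or still open speak of the compounds shown alone.

Measured compounds:
compound 1 `CCCCNc1nc(NCc2ccco2)c2ccccc2n1` — 66.7%
compound 2 `Fc1ccc2nc(NCCCCN3CCN(c4cccc(Cl)c4Cl)CC3)nc(NCc3ccco3)c2c1` — "not determined" (no result reported)
compound 3 `Cc1cccc(N2CCN(CCCCNc3nc(NCc4ccco4)c4cc(F)ccc4n3)CC2)c1C` — 97.7%

In a functional assay on MCF7 cells (Homo sapiens) for cytotoxicity, read by MTT assay, with a stated time of 2 days, tested at 10 uM (a lower number here means less inhibition, a higher number more inhibition at the concentration tested (going by the name of the read-out)), compound 1 gives 66.7%. Compound 3, carrying the fluoro substituent and the piperazine side chain, gives 97.7% in this assay. For compound 2 the entry in this assay is "not determined" (no result reported), so it cannot be placed against either of the others; its standing rests only on its structure, which shares the fluoro ring carbon with compound 3.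

Compound 4 `Clc1cccc(N2CCN(CCCCNc3nc(NCc4ccco4)c4ccccc4n3)CC2)c1Cl` is the unmeasured analogue of compound 2. The change is hydrogen in place of fluoro on an aromatic carbon, leaving the furan-methylamino group and the dichlorophenyl-piperazine chain untouched. For the measured compounds named here, with no measured pair showing this change, the expected step in this assay is none beyond the scatter, in either direction. Compound 4 is expected to sit near 88%, within 65% to 100%, given that compound 3 with the same chain type reaches 97.7%.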

Compound 4, a percentage reported as inhibition, at one concentration (the size of the read-out at that concentration, not a potency): 95.8%
The estimate for compound 4 lay 7.8 percentage points below the measured number; the measured number falls inside the stated range.
By their numbers in this assay, from the lowest: compound 1; then compounds 4 and 3 (each within the scatter of the next).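

Compound 4 yields no readable step, as its fluoro partner, compound 2, offers no number for comparison in this assay. The compounds shown leave open whether exchanging fluoro for hydrogen changes inhibition in this assay. No supporting data bear on this result.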